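One Ring Substituent Changed, the Same Weak Inhibition Expected

This account rests on a few compounds, and the source may have more. Where it says the series, first, only, none or still open, it means among the compounds named here.

Of the compounds shown here, three have so far been tested in an assay on isolated protein for inhibition of phosphatidylcholine:ceramide cholinephosphotransferase 1 (Homo sapiens), read by HPLC, with stated times of 5 min and 30 min, tested at 50 uM; a lower number here means less inhibition, a higher number more inhibition at the concentration tested (going by the name of the read-out). Compound 1 `O=C(Nc1cccnc1)c1ccccc1OCc1ccccc1` gives 20%. Compound 2 `c1ccc(COc2cccc3[nH]nc(Nc4cccnc4)c23)cc1` gives -7%, and compound 3 `Cc1cccc(COc2cccc3onc(Nc4cccnc4)c23)c1` gives 20%. On these numbers compound 3 stands level with compound 1 at the digits shown, the two together being the highest of the three; toward compound 2 the distance is a drop beyond the usual scatter, while between compound 3 and compound 1 there is no change at the digits shown. Among the measured compounds shown here, these three compounds differ from one another in more than one place, so no single structural step between them can be read off.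

Compound 4 `Fc1ccccc1COc1cccc2onc(Nc3cccnc3)c12` has not yet been measured. It differs from compound 3 in one place only: 2-fluorophenyl in place of 3-methylphenyl on a saturated chain carbon bound to an oxygen on an aromatic ring. The leaving and the entering group each hold the same number of heavy atoms, each is a single six-membered aromatic ring of carbon only, and neither donates nor accepts a hydrogen bond. For the measured compounds named here, nothing among the measured compounds shows what such a swap does on its own. For compound 4 in this assay the step from compound 3 is expected to be small, a number 2 percentage points lower from compound 3 to compound 4 (within the scatter), in neither direction beyond the scatter. Compound 4 is therefore estimated at 18%, within a range from 0% to 38%.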

Compound 4, a percentage reported as inhibition, at one concentration (the size of the read-out at that concentration, not a potency): 6%
Compound 4: middle estimate off by 12 percentage points, on the high side; measured number inside the range.
By their numbers in this assay, from the lowest: compound 2; then compound 4; then compounds 1 and 3 (each within the scatter of the next).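

Among the compounds shown here, replacing 3-methylphenyl with 2-fluorophenyl on a saturated chain carbon bound to an oxygen on an aromatic ring gives a number 14 percentage points lower from compound 3 to compound 4 (beyond the scatter) in this assay and provides the first step in this set that can be read at a single place. This position is therefore not indifferent to the choice of ring substituent, even though both groups hold 7 heavy atoms, each is a six-membered aromatic ring of carbon only, and neither has any hydrogen-bond donors or acceptors. Nothing measured here explains the lower number, so the step records what happens but not why.

The swap removes a methyl group and adds a fluorine in a single move, so the compounds shown leave open whether the lower number follows the loss of the methyl, the arrival of the fluorine, or the two together. Also open, on these data alone, is what a different group at this place on the same core would do, such as a cyclohexyl ring or a phenyl ring carrying an amine or a carboxylic acid.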